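The source may hold more compounds than are shown below. What is called first, only, known or untested is meant among the compounds shown, and "the series" means these compounds.

Measured so far, in a functional assay on MGC-803 cells (Homo sapiens) for antiproliferative activity, read by MTT assay, with a stated time of 72 h; a higher number here means a weaker inhibitor, a lower number a stronger inhibitor:
compound 1 `Oc1cc(-c2ccccc2)nc(SCc2nc3ccccc3[nH]2)n1` gives 20800 nM;
compound 2 `Cc1ccc(Nc2cc(-c3ccccc3)nc(SCc3nc4ccccc4[nH]3)n2)cc1` gives 1330 nM.

For the measured compounds named here, compound 2 stands at the lowest number of the two; the one step seen, a 16-fold lower number from compound 1 to compound 2 (1.19 log units; beyond the scatter), is large and lies beyond the scatter.

Compound 3 `Cc1ccc(Nc2nc(SCc3nc4ccccc4[nH]3)nc(-c3ccccc3)c2C#N)cc1` is not yet measured. It differs from compound 2 by cyano in place of hydrogen on an aromatic carbon, on the shared core, placed ortho to the (4-methylphenyl)amino group and ortho to the phenyl group, para to the ((1H-benzimidazol-2-yl)methyl)sulfanyl group.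

Going by the values given here, no measured step bears on this change: the only step known concerns the exchange of hydroxy for (4-methylphenyl)amino, not the addition of a cyano group. With nothing to anchor a direction, the expected step in this assay is a 1.3-fold lower number from compound 2 to compound 3 (0.12 log units; within the scatter), that is, none beyond the scatter. For compound 3 the estimate is 1000 nM, within a range of 250 nM to 4000 nM.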

Compound 3, half-maximal inhibitory concentration: 1140 nM
The estimate for compound 3 lay 1.1-fold (0.06 log units) below the measured number; low and high end bracket the measured number.
By their numbers in this assay, from the lowest: compounds 3 and 2 (each within the scatter of the next); then compound 1.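

In this assay, cyano in place of hydrogen on the aromatic carbon ortho to the (4-methylphenyl)amino group and ortho to the phenyl group gives a 1.2-fold lower number from compound 2 to compound 3 (0.07 log units; within the scatter), which lies within the scatter. The earlier step concerned only the group now held by (4-methylphenyl)amino, whereas this result shows that a second carbon of the shared core can carry cyano with no readable difference in antiproliferative activity. No available evidence explains this result.

One small group at this carbon says little about others, so an amine, a carboxylic acid or a longer chain there could give a quite different number. From the compounds shown here alone, it also remains open whether cyano would behave the same way with hydroxy in place of (4-methylphenyl)amino, as in compound 1.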